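Dropping a Chloro Substituent: Expected Effect on Cell Inhibition

The source may hold more compounds than are shown below. What is called first, only, known or untested is meant among the compounds shown, and "the series" means these compounds.

Compound 1 `COC(=O)c1c(C)cccc1OC(=O)COc1cc(O)c2c(=O)cc(-c3ccccc3)oc2c1` gives 37200 nM in a functional assay on cells (T-cell, Mus musculus, strain BALB/c) for inhibition, read by MTT assay, with a stated time of 72 h; on this read-out lower numbers stand for stronger inhibition and higher numbers for weaker inhibition.
Compound 2 `COC(=O)c1c(Cl)cccc1OC(=O)COc1cc(O)c2c(=O)cc(-c3ccccc3)oc2c1` gives 38900 nM in this assay.

Going by the values given here, compound 2 stands at the higher of the two numbers, but its only neighbour, compound 1, lies within the scatter of it, so the two cannot be ordered. Among the compounds with values here, the single measured step, a 1.0-fold higher number from compound 1 to compound 2 (0.02 log units; within the scatter), shows that exchanging methyl for chloro at this position moves nothing beyond the scatter. Compound 3 `COC(=O)c1ccccc1OC(=O)COc1cc(O)c2c(=O)cc(-c3ccccc3)oc2c1` takes the next step away from compound 2: hydrogen in place of chloro on an aromatic carbon. Within the data shown here, no measured pair shows exactly this exchange; the one step touching the same position, a 1.0-fold higher number from compound 1 to compound 2 (0.02 log units; within the scatter), left the number essentially unchanged, which suggests a small substituent swap there is tolerated without a shift. The expected step, a 1.0-fold lower number from compound 2 to compound 3 (0.01 log units; within the scatter), is therefore no change beyond the scatter. Compound 3 is estimated at 38000 nM, with a range from 19000 nM to 76000 nM.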

Compound 3, half-maximal inhibitory concentration: 28500 nM
For compound 3 the middle estimate is 1.3-fold (0.12 log units) above the measured one; the range from low to high includes it.
By their numbers in this assay, from the lowest: compounds 3, 1 and 2 (each within the scatter of the next).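

With compound 3, the position ortho to a methoxycarbonyl group carries only hydrogen, and in this assay both the step of a 1.4-fold lower number from compound 2 to compound 3 (0.14 log units; within the scatter) and the step of a 1.3-fold lower number from compound 1 to compound 3 (0.12 log units; within the scatter) stay within the scatter. The earlier pair compared two substituents with each other, whereas this result adds the unsubstituted ring as a reference, so chloro, methyl and hydrogen at this position cannot be told apart on this read-out. Nothing available here offers an explanation for this.

These three compounds leave open whether an amine, a methoxy group or a longer chain at the same position would move the number beyond the scatter. Going by these compounds, all three also keep the methoxycarbonyl group, so the effect of exchanging it for a carboxylic acid remains unknown.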